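The compounds below may be only part of what the source reports. "The series", "measured", "known", "first", "only" and "open" are said of these compounds alone.

Measured compounds:
compound 1, `O=C(NO)c1ccc(/C=C/c2ccnc(-c3cc(F)ccc3O)c2)cc1`, with 1920 nM
compound 2, `O=C(NO)c1ccc(/C=C/c2ccnc(-c3cccc(CO)c3)c2)cc1`, with 1740 nM
compound 3, `Cc1ccc(-c2cc(/C=C/c3ccc(C(=O)NO)cc3)ccn2)cc1`, with 1910 nM

In a functional assay on MGC-803 cells (Homo sapiens) for antiproliferative activity, read by CellTiter-Glo, with a stated time of 72 h (on this read-out lower numbers stand for stronger inhibition and higher numbers for weaker inhibition), compound 1 gives the highest of the three numbers, but only just: the step of a 1.0-fold lower number from compound 1 to compound 3 (0.00 log units; within the scatter) and the step of a 1.1-fold lower number from compound 1 to compound 2 (0.04 log units; within the scatter) both sit within the scatter, so the three compounds cannot be told apart on this read-out. Compound 4, `Cc1ccc(-c2cc(/C=C/c3ccc(C(=O)NO)cc3)ccn2)c(F)c1`, has not yet been measured in this assay. It differs from compound 1 in one place: 2-fluoro-4-methylphenyl in place of 5-fluoro-2-hydroxyphenyl on an aromatic carbon.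

The two measured steps that bear on this change both start from compound 1 and swap the same 5-fluoro-2-hydroxyphenyl group for another aryl group on the shared core, and neither moved the number beyond the scatter. For the measured compounds named here, the closer analogue is compound 3, which carries the 4-methylphenyl group and gives 1910 nM; compound 4 adds only a fluorine to that group to give 2-fluoro-4-methylphenyl, and no step between compound 3 and compound 4 has been measured. On this basis the expected step of a 1.0-fold lower number from compound 1 to compound 4 (0.00 log units; within the scatter) is none beyond the scatter. Compound 4 is therefore estimated at 1900 nM in this assay, with a range from 900 nM to 4000 nM.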

Compound 4, half-maximal inhibitory concentration: 770 nM
Beside the measured number, compound 4's estimate is 2.5-fold (0.39 log units) above it; measured number outside the range, below it.
By their numbers in this assay, from the lowest: compound 4; then compounds 2, 3 and 1 (each within the scatter of the next).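

The three earlier aryl groups could not be told apart in this assay, so this position, next to the ring nitrogen, had shown no response to the changes tried. For the compounds shown here, the clearest reading is a 2.5-fold lower number from compound 3 to compound 4 (0.39 log units; beyond the scatter), where the only change is fluoro in place of hydrogen on an aromatic carbon, and this shows that a single added atom on the aryl group can move the number beyond the scatter. The 2-fluoro-4-methylphenyl group also stands apart from the other two aryl groups, with a 2.5-fold lower number from compound 1 to compound 4 (0.40 log units; beyond the scatter) and a 2.3-fold lower number from compound 2 to compound 4 (0.35 log units; beyond the scatter), though all three steps are modest, and nothing available here accounts for the shift.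

The compounds shown leave open whether the fluoro group alone carries this step or acts only together with the 4-methyl group, and whether chloro, methoxy or trifluoromethyl in its place would give a lower number still. They also leave open how an amine or a carboxylic acid on this aryl ring would read in this assay.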